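Restoring a Carbonyl on the Piperazine Nitrogen

The compounds below may be only part of what the source reports. "The series", "measured", "known", "first", "only" and "open" are said of these compounds alone.

Compound 1 `O=C(c1cc(Cl)ccn1)N1CCN(c2nccc(Oc3cc(Cl)cc(Cl)c3)n2)CC1`: 16700 nM
Compound 2 `O=S(=O)(c1ccccc1)N1CCN(c2nccc(Oc3cc(Cl)cc(Cl)c3)n2)CC1`: > 50000 nM
Compound 3 `O=C(Nc1ccc2ccccc2c1)N1CCN(c2nccc(Oc3cc(Cl)cc(Cl)c3)n2)CC1`: 46800 nM

In a functional assay on MDA-MB-231 cells (Homo sapiens) for antiproliferative activity, read by MTT assay, with a stated time of 24 h (a higher number here means a weaker inhibitor, a lower number a stronger inhibitor), compound 1 gives 16700 nM and compound 3 gives 46800 nM. For compound 2 only a limit of the assay is known, > 50000 nM (the limit of > 50000 nM in this assay, at which 1 of the 3 values shown sits). Compound 4 `CN1CCN(CC(=O)N2CCN(c3nccc(Oc4cc(Cl)cc(Cl)c4)n3)CC2)CC1` differs from compound 2 as follows: ((4-methylpiperazin-1-yl)methyl)carbonyl in place of phenylsulfonyl on an amine nitrogen in a ring. The step that bears most directly on this change is an at least 2.9-fold higher number from compound 1 to compound 2 (0.47 log units; beyond the scatter), which ran the opposite way at the same ring nitrogen; the step of a 2.8-fold higher number from compound 1 to compound 3 (0.45 log units; beyond the scatter) shows that the group on the carbonyl also moves the number modestly. A step back toward a lower number is therefore expected, an at least 1.6-fold lower number from compound 2 to compound 4 (0.22 log units; that floor lies within the scatter), though a second limit remains possible. Compound 4 is estimated at 30000 nM, with a range of 12000 nM to 70000 nM.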

Compound 4, half-maximal inhibitory concentration: 24700 nM
The estimate for compound 4 lay 1.2-fold (0.08 log units) above the measured number; the measured number falls inside the stated range.
By their numbers in this assay, from the lowest: compounds 1, 4 and 3 (each within the scatter of the next, the first and the last beyond it). At a limit, above all of these: compound 2.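

In this assay, compound 2 is known only as a limit, not a number: the limit of > 50000 nM in this assay, at which 1 of the 4 values shown sits. The step reads an at least 2.0-fold lower number from compound 2 to compound 4 (0.30 log units; that floor lies within the scatter), so it does not by itself establish a change beyond the scatter on the amine nitrogen in a ring. With a 1.9-fold lower number from compound 3 to compound 4 (0.28 log units; within the scatter) and a 1.5-fold higher number from compound 1 to compound 4 (0.17 log units; within the scatter), (4-methylpiperazin-1-yl)methyl on the carbonyl carbon stands within the scatter of both earlier carbonyl groups, although those two differ beyond it. Going by these compounds, it remains open whether a carboxylic acid or a longer chain ending in an amine on that carbonyl carbon would fall beyond the scatter of compound 1.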